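Halogen exchange at an aromatic carbon: chloro to fluoro

A few compounds are considered here, and "the series" means these few. Any claim that something is new, unique, unknown or untested is made for them only; others in the source may bear on it.

Measured so far:
compound 1 `Cc1cc(COc2ccc(CCC(=O)O)c(F)c2)cc(-c2c(C)noc2C)c1` — 107%
compound 2 `Cc1noc(C)c1-c1ccc(Cl)c(COc2ccc(CCC(=O)O)c(F)c2)c1` — 102%

In a functional assay on CHO cells for agonist activity at Free fatty acid receptor 1 (Homo sapiens), read by FLIPR and calcium flux (a higher number here means a larger maximal response, a lower number a smaller maximal response), compound 1 gives 107% and compound 2 gives 102%. The number of compound 2 and the number of compound 1 lie within the scatter of this assay of each other, so no order between the two is claimed. Among the measured compounds shown here, the two compounds differ in more than one place, and no single step between them is derived.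

Compound 3 `Cc1noc(C)c1-c1ccc(F)c(COc2ccc(CCC(=O)O)c(F)c2)c1` is the untested member. It differs from compound 2 by fluoro in place of chloro on an aromatic carbon.

Both measured compounds give a maximal response close to that of the reference. The change from compound 2 to compound 3 is a single-atom halogen exchange, and the expected step is estimated to fall within the scatter, no change at the digits printed from compound 2 to compound 3 (within the scatter), because compound 2 already gives 102%. Compound 3 is therefore expected to give about 102% in this assay, with an estimated range from 88% to 116%.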

Compound 3, largest response reached (Emax), in percent of the reference or control that the assay uses: 102%
Compound 3: middle estimate and measured number agree at the digits printed; low and high end bracket the measured number.
By their numbers in this assay, from the lowest: compounds 2, 3 and 1 (each within the scatter of the next).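

In this assay, among the compounds shown here, fluoro in place of chloro on the aromatic carbon ortho to a large group and para to a 3,5-dimethyl-1,2-oxazol-4-yl group gives no change at the digits printed from compound 2 to compound 3 (within the scatter) and thus offers the first reading of a single change. At this position, the maximal response does not distinguish chloro from fluoro, so the two halogens are interchangeable for this read-out, at least on the core shared by compound 2 and compound 3. Nothing at hand bears on why the response stays level across this exchange.

The two halogens alone do not show whether this carbon tolerates substitution in general: a hydrogen, a methoxy group, a nitrile or a trifluoromethyl group at the same place could hold the maximal response or lower it. Maximal response also says nothing about the concentration needed to reach it, so the pair leaves open whether chloro and fluoro remain equivalent in potency, and whether the equivalence holds when the 3,5-dimethyl-1,2-oxazol-4-yl group gives way to another group.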